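The source may hold more compounds than are shown below. What is called first, only, known or untested is meant among the compounds shown, and "the series" means these compounds.

Compounds measured so far:

Compound 1, `CCOC(=O)c1csc2nc(CN3CCN(C)CC3)c(-c3ccc(C)cc3)n12`: 61000 nM
Compound 2, `CCOC(=O)c1csc2nc(CN3CCN(C)CC3)c(-c3ccc(OC)cc3)n12`: 44600 nM
Compound 3, `CC(=O)NNC(=O)c1csc2ncc(-c3ccc(C)cc3)n12`: 71800 nM

All three were tested in a functional assay on HCT-116 cells (Homo sapiens) for antiproliferative activity, read by MTT assay, with a stated time of 72 h; on this read-out higher numbers stand for weaker inhibition and lower numbers for stronger inhibition. Compound 1 gives 61000 nM and compound 2 gives 44600 nM in this assay; the two differ by one change, (methoxy in place of methyl on an aromatic carbon), and that change made a step of a 1.4-fold lower number from compound 1 to compound 2 (0.14 log units; within the scatter). Compound 3, tested in this assay, gives 71800 nM; its values and those of compound 1 and compound 2 all lie within the usual scatter of one another, so no order among them can be read from these numbers. Compound 3 is built on a different core from compound 1; the difference between the two cores is not broken down here.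

Compound 4, `COc1ccc(-c2cnc3scc(C(=O)NNC(C)=O)n23)cc1`, has not yet been measured. It differs from compound 3 by methoxy in place of methyl on an aromatic carbon, the same change, at the same kind of place, that turned compound 1 into compound 2. Because that earlier change made only a step of a 1.4-fold lower number from compound 1 to compound 2 (0.14 log units; within the scatter), a similarly small step, a 1.4-fold lower number from compound 3 to compound 4 (0.14 log units; within the scatter), is expected here. Compound 4 is therefore estimated to give 52000 nM in this assay, most likely between 25000 nM and 110000 nM.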

Compound 4, half-maximal inhibitory concentration: 17000 nM
Beside the measured number, compound 4's estimate is 3.1-fold (0.49 log units) above it, outside the stated range (below it).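

In this assay, putting methoxy in place of methyl on the aromatic ring gave a 4.2-fold lower number from compound 3 to compound 4 (0.63 log units; beyond the scatter), a modest but real step toward stronger inhibition. The size of the effect of this change therefore did not carry over unchanged from one core to the other: the same change on two cores in this assay, a 1.4-fold lower number (0.14 log units; within the scatter) from compound 1 to compound 2 and a 4.2-fold lower number (0.63 log units; beyond the scatter) from compound 3 to compound 4, 3.1-fold (0.49 log units) apart, beyond the scatter of two such steps.

This does not show which feature of the two parent compounds sets the size of the step, as compound 1 and compound 3 differ in more than one place, and a single pair on each core cannot reveal a general rule for the series. The compounds shown also leave open how other groups at this place on the ring would behave on either core, such as a chlorine atom, a hydroxyl or a longer chain like ethoxy. Going by these compounds, it likewise remains open whether compound 3's acetyl hydrazide side chain, rather than the ring system itself, is what makes the step from methyl to methoxy larger on that core.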